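A Fluoro Swap on the Phenylsulfanyl Ring

A few compounds are considered here, and "the series" means these few. Any claim that something is new, unique, unknown or untested is made for them only; others in the source may bear on it.

Compound 1 `O=C1C[C@H](O)C[C@@H](/C=C/c2cnc3c(F)c(F)c(F)cc3c2Sc2ccccc2)O1` was tested in an assay (strain Holtzman-Sprague-Dawley) for inhibition of 3-hydroxy-3-methylglutaryl-coenzyme A reductase (Rattus norvegicus), with a stated time of 30 min (on this read-out higher numbers stand for weaker inhibition and lower numbers for stronger inhibition), where compound 1 gives 10700 nM. That is the higher of the two numbers at hand; compound 2 `CC(C)c1ccc(Sc2cc3c(Sc4ccc(C(C)C)cc4)c(/C=C/[C@@H]4C[C@@H](O)CC(=O)O4)cnc3c(Sc3ccc(C(C)C)cc3)c2Sc2ccc(C(C)C)cc2)cc1` gives 4350 nM, a lower number. Compound 3 `O=C1C[C@H](O)C[C@@H](/C=C/c2cnc3c(F)c(F)c(F)cc3c2Sc2ccc(F)cc2)O1` has not been measured yet. It differs from compound 1 by one change: fluoro in place of hydrogen on an aromatic carbon. Nothing measured here shows what such a change does in this assay, so the expected step, a 1.2-fold lower number from compound 1 to compound 3 (0.08 log units; within the scatter), is small and has no clear direction beyond the scatter. Compound 3 is therefore estimated at 9000 nM, most likely falling between 4000 nM and 25000 nM.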

Compound 3, half-maximal inhibitory concentration: 7930 nM
Estimate against measurement, compound 3: 1.1-fold (0.05 log units) above; measured number inside the range.
By their numbers in this assay, from the lowest: compounds 2, 3 and 1 (each within the scatter of the next, the first and the last beyond it).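

In this assay, fluoro in place of hydrogen on the phenylsulfanyl ring, para to a large group, gives a 1.3-fold lower number from compound 1 to compound 3 (0.13 log units; within the scatter), a step within the usual scatter. This position therefore accepts a fluoro group, but the assay cannot separate this swap from no change at all. No measured evidence here bears on the result. Still open, as far as these compounds go, is whether a larger group at this same place, such as a methoxy group, an amine or a carboxylic acid, would move the number beyond the scatter.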